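A few compounds are considered here, and "the series" means these few. Any claim that something is new, unique, unknown or untested is made for them only; others in the source may bear on it.

In an assay on isolated protein for inhibition of Nitric oxide synthase, inducible (Homo sapiens), with a stated time of 30 min, tested at 1 mM (a higher number here means more inhibition at the concentration tested (going by the name of the read-out), a lower number less inhibition), compound 1 `COc1ccc(N)c(C2=NN(C(=O)C3CCC3)CC2)c1` gives 1.91%. Compound 2 `COc1cc(N)c(C2=NN(C(=O)C3CC3)CC2)cc1OC` gives 25.2%. Compound 3 `COc1cc(N)c(C2=NN(C(=O)C3CC3)CC2)c(OC)c1OC` gives 30.1%.

Compound 3 has the highest of the three numbers, but its gap to compound 2, a number 4.9 percentage points higher from compound 2 to compound 3 (within the scatter), lies within the scatter, so the two cannot be ranked; only compound 1 stands clearly lower, beyond the scatter. Compound 4 `COc1cc(N)c(C2=NN(C(=O)CCc3ccccc3)CC2)c(OC)c1OC` differs from compound 3 in one place: phenethyl in place of cyclopropyl on a carbonyl carbon. Among the compounds with values here, no measured step touches this carbonyl group; the only step, a methoxy change elsewhere, was within the scatter and gives no guidance here. Without a bearing step, no shift beyond the scatter is expected, and the estimate for compound 4 is 30%, between 10% and 55%, a step of a number 0.1 percentage points lower from compound 3 to compound 4 (within the scatter).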

Compound 4, a percentage reported as inhibition, at one concentration (the size of the read-out at that concentration, not a potency): 18.3%
Compound 4: middle estimate off by 11.7 percentage points, on the high side; the range from low to high includes it.
By their numbers in this assay, from the lowest: compound 1; then compounds 4, 2 and 3 (each within the scatter of the next, the first and the last beyond it).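

Putting phenethyl in place of cyclopropyl on the carbonyl carbon gives a number 11.8 percentage points lower from compound 3 to compound 4 (beyond the scatter), so unlike the methoxy step, this change at this position moves the read-out beyond the scatter. The position therefore responds to the group it carries, and here the entering group, with an aromatic ring, goes with less inhibition at the concentration tested. Nothing available explains this step.

From the compounds shown here alone, it remains open whether the aromatic ring, the chain or the departure of cyclopropyl matters most. A benzyl or plain propyl group on the same carbonyl carbon would help separate these.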